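Moving a Hydroxyl Group: From Compound 3 to Compound 4

The compounds below may be only part of what the source reports. "The series", "measured", "known", "first", "only" and "open" are said of these compounds alone.

Compound 1 `Oc1cccc(-c2cc(-c3cccs3)cc(-c3ccccc3O)n2)c1` in a functional assay on HeLa cells (Homo sapiens) for cytotoxicity, read by CCK-8 assay (on this read-out higher numbers stand for weaker inhibition and lower numbers for stronger inhibition), gives only a limit, > 50000 nM.
Compound 2 `Oc1cccc(-c2cc(-c3ccco3)cc(-c3ccccc3O)n2)c1` in this assay gives only a limit, > 50000 nM.
Compound 3 `Oc1ccccc1-c1cc(-c2ccoc2)cc(-c2ccccc2O)n1` in this assay gives only a limit, > 50000 nM.

Compound 3 therefore stands at the limit of this assay, and the two other measured compounds stand there as well; all three share (the limit of > 50000 nM in this assay, at which 3 of the 3 values shown sit), so none of them can be placed in order against another. Among the measured compounds shown here, the only step between compounds that differ in one place, a step that the two limits leave unreadable from compound 1 to compound 2, swaps thiophen-2-yl for furan-2-yl; its size is not readable, both of its ends being limits.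

Compound 4 `Oc1cccc(-c2cc(-c3ccoc3)cc(-c3ccccc3O)n2)c1` has the same atoms as compound 3, joined differently: 3-hydroxyphenyl in place of 2-hydroxyphenyl on an aromatic carbon. For the measured compounds named here, no measured step bears directly on this change, and the single measured step offers no size to build on. The expectation is accordingly a step of no size beyond the scatter, with compound 4 remaining at the limit of this assay just as compound 3 does. The step that the limit leaves unreadable from compound 3 to compound 4 is estimated to be flat. Compound 4 is expected to give about 80000 nM, between 30000 nM and 300000 nM, and most probably to be reported only as a limit once more.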

Compound 4, half-maximal inhibitory concentration: > 50000 nM
Compound 4 was reported as a limit; the forecaster's own chance of this, stated with the estimate: 85%; the middle value does not contradict the limit.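

In this assay compound 4 gives > 50000 nM, which is a limit. Among the compounds shown here, no step from compound 1, compound 2 or compound 3 to compound 4 can be read, so the four compounds cannot be ordered: the limit of > 50000 nM in this assay, at which 4 of the 4 values shown sit. The compounds shown leave open whether swapping 2-hydroxyphenyl for 3-hydroxyphenyl, or exchanging thiophen-2-yl, furan-2-yl and furan-3-yl, changes the read-out at all.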